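Removing the amine nitrogen from a two-compound series

The source may hold more compounds than are shown below. What is called first, only, known or untested is meant among the compounds shown, and "the series" means these compounds.

In a functional assay on MDA-MB-231 cells (Homo sapiens) for inhibition, read by WST assay, with a stated time of 4 days (a higher number here means a weaker inhibitor, a lower number a stronger inhibitor), compound 1 `CC[C@H](N)C(=O)N[C@H]1CCCC[C@H]2CC[C@@H](C(=O)NC(c3ccccc3)c3ccccc3)N2C1=O` gives 8000 nM and compound 2 `CC[C@H](NC)C(=O)N[C@H]1CCCC[C@H]2CC[C@@H](C(=O)NC(c3ccccc3)c3ccccc3)N2C1=O` gives 410 nM, which makes compound 2 the stronger inhibitor of the two. Compound 3 `C[C@H](O)C(=O)N[C@H]1CCCC[C@H]2CC[C@@H](C(=O)NC(c3ccccc3)c3ccccc3)N2C1=O` differs from compound 2 in one place: 1-hydroxyethyl in place of 1-(methylamino)propyl on a carbonyl carbon. In words, this is 1-hydroxyethyl in place of 1-(methylamino)propyl on a carbonyl carbon. Within the data shown here, only one measured step bears on this change, a 20-fold lower number from compound 1 to compound 2 (1.29 log units; beyond the scatter), a large step in which methyl replaced hydrogen on the amine nitrogen. Compound 3 has no such nitrogen, so no measurement covers this change directly. The nearest guide is compound 1, which sits at 8000 nM without that methyl. A large rise in the number is therefore expected, an estimated 37-fold higher number from compound 2 to compound 3 (1.56 log units; beyond the scatter). For compound 3 the expected value is 15000 nM, with an estimated range of 4000 nM to 60000 nM.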

Compound 3, half-maximal inhibitory concentration: 7000 nM
Beside the measured number, compound 3's estimate is 2.1-fold (0.33 log units) above it; the measured number falls inside the stated range.
By their numbers in this assay, from the lowest: compound 2; then compounds 3 and 1 (each within the scatter of the next).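

In this assay, replacing 1-(methylamino)propyl with 1-hydroxyethyl gives up most of what the methyl group had gained (a 17-fold higher number from compound 2 to compound 3 (1.23 log units; beyond the scatter)). Replacing the 1-aminopropyl group of compound 1 with the same 1-hydroxyethyl group makes no difference that can be told from scatter (a 1.1-fold lower number from compound 1 to compound 3 (0.06 log units; within the scatter)), so among these three compounds only the 1-(methylamino)propyl group stands apart. No measurement shown here explains this result.

This change swaps the nitrogen group for a hydroxyl and shortens the chain at the same time, so the two effects cannot be separated here; a 1-hydroxypropyl or 1-(methylamino)ethyl group would tell them apart. Among these compounds, also open is how a larger group on the nitrogen, such as ethyl, or a second methyl would compare with the single methyl of compound 2.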